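The source may hold more compounds than are shown below. What is called first, only, known or untested is meant among the compounds shown, and "the series" means these compounds.

Measured in a functional assay on A-375 cells (Homo sapiens) for antiproliferative activity; on this read-out higher numbers stand for weaker inhibition and lower numbers for stronger inhibition:
Compound 1 `O=C(Nc1ccc(-c2cscn2)cc1)C1CCCN(Cc2ccc(F)c(F)c2)C1`: 880 nM
Compound 2 `O=C(Nc1ccc(-c2cscn2)cc1)[C@@H]1CCCN(Cc2ccc(F)c(F)c2)C1`: 6000 nM
Compound 3 `O=C(Nc1ccc(-c2cscn2)cc1)[C@H]1CCCN(Cc2ccc(F)c(F)c2)C1`: 190 nM

Compound 2 stands at the weak end of this set, with the highest number of the three. Compound 4 `O=C(Nc1ccc(-c2ccc[nH]2)cc1)[C@@H]1CCCN(Cc2ccc(F)c(F)c2)C1` keeps its configuration but has 1H-pyrrol-2-yl in place of 1,3-thiazol-4-yl on an aromatic carbon. The measured steps concern configuration only: a 6.8-fold higher number from compound 1 to compound 2 (0.83 log units; beyond the scatter) goes with the fact that one of compounds 1 and 2 is drawn with a defined configuration and the other without, at the place where they differ, a 4.6-fold lower number from compound 1 to compound 3 (0.67 log units; beyond the scatter) with the fact that one of compounds 1 and 3 is drawn with a defined configuration and the other without, at the place where they differ, and the large 32-fold lower number from compound 2 to compound 3 (1.50 log units; beyond the scatter) with the fact that compounds 2 and 3 differ only in the configuration as drawn. None of them alters this ring, so they give no direction for the swap, and the expectation stays anchored on compound 2 at 6000 nM, with no step beyond the scatter. The expected step is a 1.2-fold lower number from compound 2 to compound 4 (0.08 log units; within the scatter). Compound 4 is estimated at 5000 nM, with an expected range from 1500 nM to 18000 nM.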

Compound 4, half-maximal inhibitory concentration: 18000 nM
The estimate for compound 4 lay 3.6-fold (0.56 log units) below the measured number; low and high end bracket the measured number.
By their numbers in this assay, from the lowest: compound 3; then compound 1; then compound 2; then compound 4.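

In this assay, the group on this aromatic carbon turns out to matter as well as the configuration: 1H-pyrrol-2-yl in place of 1,3-thiazol-4-yl gives a 3.0-fold higher number from compound 2 to compound 4 (0.48 log units; beyond the scatter), a modest change. The change swaps a ring with two hetero atoms for one with a single hetero atom and adds a hydrogen-bond donor, but nothing shown explains the step. Going by these compounds, whether the swap acts the same way in the configuration of compound 3 stays open. So does how a phenyl ring or an amine would fare here.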